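The source may report more compounds than this note shows. Statements on the series, on what has been measured and on what is new or still open speak of the compounds shown alone.

Measured compounds:
compound 1 `Cc1cc(C(=O)O)c(C)n1-c1ccc(Cl)c(C(F)(F)F)c1` gives 2100 nM in an assay on cells for inhibition of Palmitoleoyl-protein carboxylesterase NOTUM variant C330S (Homo sapiens), read by fluorescence, with a stated time of 40 min; a higher number here means a weaker inhibitor, a lower number a stronger inhibitor
compound 2 `Cc1ccc(-n2c(C)cc(C(=O)O)c2C)cc1` gives 2000 nM in this assay

Compound 2 holds the lowest of the two numbers, though the gap to compound 1 lies within the scatter, so no order between the two can be read from these values. For the measured compounds named here, no pair of measured compounds differing in a single place is available, so no measured step exists yet.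

Compound 3 `Cc1cc(C(=O)O)c(C)n1-c1ccc(Cl)cc1` is not yet measured. It differs from compound 2 by chloro in place of methyl on an aromatic carbon. Going by the values given here, with only compound 1 and compound 2 known, and both giving half-maximal inhibitory concentrations within the scatter of each other, there is no basis for a step of any size in this assay, and a step of a 1.1-fold lower number from compound 2 to compound 3 (0.02 log units; within the scatter) is the estimate, which is expected to stay within the scatter. Compound 3 is expected to give 1900 nM, with a range from 700 nM to 5000 nM.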

Compound 3, half-maximal inhibitory concentration: 860 nM
Compound 3: the middle estimate sits 2.2-fold (0.34 log units) above what was measured, within the range that was stated.
By their numbers in this assay, from the lowest: compound 3; then compounds 2 and 1 (each within the scatter of the next).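

For the compounds shown here, in (this assay), the place para to a large group on the six-membered aromatic ring responds to chloro in place of methyl, giving the first step beyond the scatter, though a modest one (a 2.3-fold lower number from compound 2 to compound 3 (0.37 log units; beyond the scatter)). Going by these compounds alone, with chloro kept, hydrogen in place of trifluoromethyl on an aromatic carbon also gives a modest step (a 2.4-fold lower number from compound 1 to compound 3 (0.39 log units; beyond the scatter)), so trifluoromethyl is not required to reach the lowest number so far. No measurement at hand bears on why either step occurs.

From the compounds shown here alone, whether a nitrile or a methoxy group at the para place would lower the number further remains open. The carboxylic acid and the methyl groups on the shared core are constant here, so the effect of an amide in place of the acid is also unknown.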